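Compound 3 to compound 4: a new amide substituent

This account rests on a few compounds, and the source may have more. Where it says the series, first, only, none or still open, it means among the compounds named here.

Among the measured compounds shown here, in a physicochemical assay for solubility, read by spectrophotometry, measured as kinetic solubility, at pH 8, tested at 500 uM (on this read-out lower numbers stand for lower solubility and higher numbers for higher solubility), compound 3 `Cn1ccc2ccc(-c3cc(Nc4cnccc4C(=O)NCc4cncnc4)cc4nccnc34)cc21` gives 233 ug/mL, the highest of the three numbers so far. Compound 1 `Cn1ccc2ccc(-c3cc(Nc4ccccc4S(N)(=O)=O)cc4nccnc34)cc21` gives 6 ug/mL, and compound 2 `Cn1ccc2ccc(-c3cc(Nc4ccccc4S(=O)(=O)NCC4CCOCC4)cc4nccnc34)cc21` gives 2 ug/mL, both far lower.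

Compound 4 `CC(=O)N1CCC(NC(=O)c2ccncc2Nc2cc(-c3ccc4ccn(C)c4c3)c3nccnc3c2)CC1` carries 1-acetylpiperidin-4-yl in place of (pyrimidin-5-yl)methyl on an amide-type nitrogen.

For the measured compounds named here, only one measured step offers any guide, and only loosely. The step of a 3.0-fold lower number from compound 1 to compound 2 (0.48 log units; beyond the scatter) puts (oxan-4-yl)methyl in place of hydrogen on a sulfonamide nitrogen, and it is modest but beyond the scatter. Going by the values given here, that step differs in both the group and the place, and no measured pair changes the group on the amide-type nitrogen. On the strength of that single step, a modest drop of similar size is expected in this assay, with wide uncertainty.

The expected step is a 2.9-fold lower number from compound 3 to compound 4 (0.46 log units; beyond the scatter).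

Compound 4 is estimated at 80 ug/mL, with an expected range of 20 ug/mL to 240 ug/mL.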

Compound 4, solubility: 213 ug/mL
Compound 4: the middle estimate sits 2.7-fold (0.43 log units) below what was measured; the range from low to high includes it.
By their numbers in this assay, from the lowest: compound 2; then compound 1; then compounds 4 and 3 (each within the scatter of the next).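

Among the compounds shown here, this is the first step read on the amide-type nitrogen: 1-acetylpiperidin-4-yl replaces (pyrimidin-5-yl)methyl with a 1.1-fold lower number from compound 3 to compound 4 (0.04 log units; within the scatter) in this assay. For this pair, the reading therefore does not depend on keeping the six-membered aromatic ring of the group that leaves, since a six-membered non-aromatic ring carrying an acetyl group gives a number within the scatter. No measurement at hand bears on the reason for this result.

On these data alone, two groups on one nitrogen cannot show how far this tolerance extends, so it remains open how an open-chain amine, a carboxylic acid or a longer chain would read at the same place. As far as these compounds go, it is also open whether the same exchange would give so small a step on a different amide of the shared core.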